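Trifluoromethylphenyl replaces methylphenyl on the shared core

A few compounds are considered here, and "the series" means these few. Any claim that something is new, unique, unknown or untested is made for them only; others in the source may bear on it.

Compound 1 `COc1ccc(-c2cc3nccc(-c4cc(OC)c(OC)c(OC)c4)n3n2)cc1N`: in a functional assay on B16-F0 cells (Mus musculus) for inhibition, read by CCK-8 assay, with a stated time of 48 h (a higher number here means a weaker inhibitor, a lower number a stronger inhibitor), compound 1 gives 88 nM.
Compound 2 `COc1cc(-c2ccnc3cc(-c4ccc5ccn(C)c5c4)nn23)cc(OC)c1OC`: compound 2 gives 657 nM.
Compound 3 `COc1cc(-c2ccnc3cc(-c4cccc(C)c4)nn23)cc(OC)c1OC`: compound 3 gives 2220 nM.

Compound 3 has the highest number of the three, so it is the weakest inhibitor in this set: the step of a 3.4-fold higher number from compound 2 to compound 3 (0.53 log units; beyond the scatter) and the step of a 25-fold higher number from compound 1 to compound 3 (1.40 log units; beyond the scatter) both lie beyond the scatter. All three measured steps change the same aryl group on the shared core, and the two that reach compound 3, a 25-fold higher number from compound 1 to compound 3 (1.40 log units; beyond the scatter) and a 3.4-fold higher number from compound 2 to compound 3 (0.53 log units; beyond the scatter), each raised the number; the step of a 7.5-fold higher number from compound 1 to compound 2 (0.87 log units; beyond the scatter) was smaller.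

Compound 4 `COc1cc(-c2ccnc3cc(-c4ccc(C(F)(F)F)cc4)nn23)cc(OC)c1OC` carries the change (4-(trifluoromethyl)phenyl in place of 3-methylphenyl on an aromatic carbon). Going by the values given here, no measured step exchanges one plain phenyl for another at this position, and none introduces a trifluoromethyl group, so the three steps say only that this position moves the number strongly when the group changes in kind. For this assay the expected outcome for compound 4 is therefore a step of about a 1.1-fold higher number from compound 3 to compound 4 (0.05 log units; within the scatter), that is no change beyond the scatter, with a wide range in both directions. Compound 4 is estimated at 2500 nM, between 800 nM and 8000 nM.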

Compound 4, half-maximal inhibitory concentration: 1770 nM
For compound 4 the middle estimate is 1.4-fold (0.15 log units) above the measured one; the measured number falls inside the stated range.
By their numbers in this assay, from the lowest: compound 1; then compound 2; then compounds 4 and 3 (each within the scatter of the next).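

In this assay, putting 4-(trifluoromethyl)phenyl in place of 3-methylphenyl gives a 1.3-fold lower number from compound 3 to compound 4 (0.10 log units; within the scatter) and so stays within the scatter: at this position on the shared core, the two substituted phenyl groups are not told apart, although the entering group carries three fluorine atoms and its substituent has a different number in the group's name. The distance to the other two groups also holds with the new group, with a 2.7-fold higher number from compound 2 to compound 4 (0.43 log units; beyond the scatter) and a 20-fold higher number from compound 1 to compound 4 (1.30 log units; beyond the scatter) both lying beyond the scatter, so the low number of compound 1 and the intermediate number of compound 2 do not depend on 3-methylphenyl being the group compared. Nothing available gives a reason for any of these differences.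

What remains open is which part of the 3-amino-4-methoxyphenyl group in compound 1 accounts for its large separation from compound 3 and compound 4, a question that calls for a phenyl bearing only an amine or only a methoxy group. An unsubstituted phenyl, or 3-(trifluoromethyl)phenyl and 4-methylphenyl, would also show separately what the substituent and its number in the name each contribute.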